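The source may report more compounds than this note shows. Statements on the series, on what has been measured and on what is new or still open speak of the compounds shown alone.

Working notes on the series, read out in an ADME assay for permeability, using PAMPA, with a stated time of 30 min, at pH 7.4; a lower number here means that the compound crosses the layer more slowly, a higher number that the compound crosses the layer faster. The three measured compounds differ only in the group on an aromatic carbon of the shared core. Compound 1 (`COc1ccc(F)cc1CNCCCNc1ccnc2cc(Cc3ccc(C#N)cc3)ccc12`) gives 23 10^-6 cm/s, compound 2 (`COc1ccc(Oc2ccc3c(NCCCNCc4cc(F)ccc4OC)ccnc3c2)cc1`) gives 317 10^-6 cm/s and compound 3 (`COc1ccc(F)cc1CNCCCNc1ccnc2cc(Oc3cccc(N(C)C)c3)ccc12`) gives 317 10^-6 cm/s. Compound 3 is therefore level with compound 2, and together they hold the highest of the three numbers.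

Compound 4 (`COc1ccc(F)cc1CNCCCNc1ccnc2cc(Oc3ccc(C(C)(C)C)cc3)ccc12`) is the next to be read. It carries 4-(tert-butyl)phenyl in place of 3-(dimethylamino)phenyl on an oxygen on an aromatic ring.

Among the compounds with values here, the closest precedent is the only measured swap on that oxygen, no change at the digits printed from compound 2 to compound 3 (within the scatter), which stays within the scatter. The two large steps, a 14-fold higher number from compound 1 to compound 2 (1.14 log units; beyond the scatter) and a 14-fold higher number from compound 1 to compound 3 (1.14 log units; beyond the scatter), both replace 4-cyanobenzyl with a phenoxy group, and compound 4 remains a phenoxy compound. Within the data shown here, no measured compound carries the tert-butyl group, so the precedent is thin.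

No step beyond the scatter is expected in this assay, and the estimated change is a 1.1-fold lower number from compound 3 to compound 4 (0.05 log units; within the scatter). For compound 4 the estimated value is 280 10^-6 cm/s, with an expected range of 130 10^-6 cm/s to 560 10^-6 cm/s.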

Compound 4, apparent permeability: 317 10^-6 cm/s
Estimate against measurement, compound 4: 1.1-fold (0.05 log units) below; the measured number falls inside the stated range.
By their numbers in this assay, from the lowest: compound 1; then compounds 2, 3 and 4 (each within the scatter of the next).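

On the oxygen on an aromatic ring, 4-(tert-butyl)phenyl in place of 3-(dimethylamino)phenyl gives no change at the digits printed from compound 3 to compound 4 (within the scatter) in this assay, so an all-carbon group with no hydrogen-bond acceptor reads the same here as a group holding a nitrogen and a hydrogen-bond acceptor. Tert-butyl in place of methoxy on an aromatic carbon of the phenoxy ring likewise gives no change at the digits printed from compound 2 to compound 4 (within the scatter) and, with a third phenoxy group now in hand, 4-(tert-butyl)phenoxy in place of 4-cyanobenzyl gives a 14-fold higher number from compound 1 to compound 4 (1.14 log units; beyond the scatter) as the same large step seen for the other two. No evidence on any property of these groups accompanies the numbers, and the flat reading among the phenoxy compounds stays without an explanation.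

The step from compound 1 changes both the atom linking the ring to the core and the group on that ring, so 4-cyanophenoxy and 4-methoxybenzyl would be needed to tell those two changes apart. From the compounds shown here alone, whether the phenoxy ring stays as tolerant with a carboxylic acid or a primary amine on it remains open.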